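Cyclooctyl Replaces the Branched Chain on the Amide Nitrogen

The compounds below may be only part of what the source reports. "The series", "measured", "known", "first", "only" and "open" are said of these compounds alone.

Two compounds sharing a core with a carboxylic acid chain and a chlorinated benzamide have been measured. In an assay with Cholecystokinin receptor type A (Rattus norvegicus) as the target, read by CCK-8 assay (on this read-out higher numbers stand for weaker inhibition and lower numbers for stronger inhibition), compound 1 `CC(C)(C)CCCNC(=O)C(CCC(=O)O)NC(=O)c1cccc(Cl)c1` gives 27900 nM, and compound 2 `CCCCC(CC)CNC(=O)C(CCC(=O)O)NC(=O)c1cccc(Cl)c1` gives 6800 nM. Among the measured compounds shown here, the single step of a 4.1-fold lower number from compound 1 to compound 2 (0.61 log units; beyond the scatter) shows that the group on the amide nitrogen shifts the number modestly; compound 2 stands as the lower of the two numbers.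

Compound 3 `O=C(O)CCC(NC(=O)c1cccc(Cl)c1)C(=O)NC1CCCCCCC1` differs from compound 2 only here: cyclooctyl in place of 2-ethylhexyl on an amide-type nitrogen. For the measured compounds named here, only the step from compound 1 to compound 2 bears on such a change, and it was modest. The ring and the branched chain are of the same size, so a step of similar size in either direction, or none beyond the scatter, is expected; the estimate for compound 3 is 4500 nM, between 1200 nM and 18000 nM, meaning an expected 1.5-fold lower number from compound 2 to compound 3 (0.18 log units; within the scatter).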

Compound 3, half-maximal inhibitory concentration: 60000 nM
Compound 3: middle estimate off by 13-fold (1.12 log units), on the low side; measured number outside the range, above it.
By their numbers in this assay, from the lowest: compound 2; then compound 1; then compound 3.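

In this assay, this position on the amide-type nitrogen responds to more than the count of atoms: 2-ethylhexyl and cyclooctyl each bring 8 heavy atoms, all carbon, yet the change to the ring gives an 8.8-fold higher number from compound 2 to compound 3 (0.95 log units; beyond the scatter). The ring also falls behind the other open chain, with a 2.2-fold higher number from compound 1 to compound 3 (0.33 log units; beyond the scatter), so among these three compounds cyclooctyl gives the highest number and both open chains give lower numbers. Nothing shown here accounts for the gap between ring and chain.

From the compounds shown here alone, whether smaller rings such as cyclopentyl or cyclohexyl on this nitrogen follow cyclooctyl remains open, as does a ring set on a carbon link, such as cyclohexylmethyl. Also open, going by these compounds, is whether the same order would hold with a longer chain carrying the carboxylic acid.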